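The source may report more compounds than this note shows. Statements on the series, on what has been measured and on what is new or still open speak of the compounds shown alone.

Three compounds have so far been run in an in vitro ADME assay on microsomes from liver (Mus musculus) for pharmacokinetics, read by LC-MS; on this read-out higher numbers stand for fast clearance and lower numbers for slow clearance:

Compound 1 `Cc1nc2cc(C(F)(F)F)ccc2n1-c1ccc(C(=O)NC2CC2)s1` — in this assay compound 1 gives > 72 mL/min/kg, which is a limit of the assay.
Compound 2 `Cc1cc(F)c2nc(C)n(-c3ccc(C(=O)NC4CC4)s3)c2c1` — in this assay compound 2 gives > 72 mL/min/kg, again a limit.
Compound 3 `Cc1cc(F)c2ncn(-c3ccc(C(=O)NC4CC4)s3)c2c1` — in this assay compound 3 gives > 72 mL/min/kg, also a limit.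

Compound 2 and compound 3 share one core and differ in a single place: hydrogen in place of methyl on an aromatic carbon. The step that the two limits leave unreadable from compound 2 to compound 3 cannot be given a size, since both of its values sit at the limit of > 72 mL/min/kg in this assay, at which 3 of the 3 values shown sit. Compound 1 carries a different core from compound 2; the difference between the two cores is not broken down here.

Compound 4 `O=C(NC1CC1)c1ccc(-n2cnc3cc(C(F)(F)F)ccc32)s1` has not yet been measured in this assay. It differs from compound 1 by hydrogen in place of methyl on an aromatic carbon, the same change as that made between compound 2 and compound 3.

The step that the limit leaves unreadable from compound 1 to compound 4 is expected, resting on compound 1 standing at > 72 mL/min/kg and on the step that the two limits leave unreadable from compound 2 to compound 3 having left the limit in place. Compound 4 is therefore estimated at 90 mL/min/kg, with a range from 55 mL/min/kg to 150 mL/min/kg in this assay, most likely again as a limit.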

Compound 4, clearance: > 72 mL/min/kg
Compound 4: no number, only a limit; the forecaster's own chance of this, stated with the estimate: 80%; the middle value is on the limit's open side.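

In this assay compound 4 gives > 72 mL/min/kg as a limit of the assay. Compound 1 also stands at a limit, so no step can be read from compound 1 to compound 4: the limit of > 72 mL/min/kg in this assay, at which 4 of the 4 values shown sit.

The compounds shown leave open what clearance each of them actually has, and whether hydrogen in place of methyl on an aromatic carbon alters it.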